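The source may hold more compounds than are shown below. What is called first, only, known or untested is meant among the compounds shown, and "the series" means these compounds.

Three analogues of a shared core were measured in an assay on cell membranes for displacement of a labelled ligand from corticotropin-releasing factor receptor 1 (Rattus norvegicus); on this read-out higher numbers stand for weaker inhibition and lower numbers for stronger inhibition. Compound 1 `CCN(CCC#N)c1nc(C)nc2c(-c3c(C)cc(OC)cc3OC)c(C)nn12` gives 2.48 nM, compound 2 `CCCN(c1nc(C)nc2c(-c3c(C)cc(OC)cc3OC)c(C)nn12)C1CC1` gives 1.48 nM, and compound 3 `C=CCN(CC=C)c1nc(C)nc2c(-c3c(C)cc(OC)cc3OC)c(C)nn12` gives 1 nM, the lowest of the three numbers, though its gap to compound 2 lies within the scatter and only its gap to compound 1 goes beyond it. Compound 4 `CCC(CC)Nc1nc(C)nc2c(-c3c(C)cc(OC)cc3OC)c(C)nn12` differs from compound 3 by (pentan-3-yl)amino in place of diallylamino on an aromatic carbon. Every measured step bears on this same position: a 1.7-fold lower number from compound 1 to compound 2 (0.22 log units; within the scatter), a 2.5-fold lower number from compound 1 to compound 3 (0.39 log units; beyond the scatter) and a 1.5-fold lower number from compound 2 to compound 3 (0.17 log units; within the scatter). All three amino variants thus sit close together, so in this assay no step beyond the scatter is expected from the new change, at most a slight drift toward a higher number. The expected step is a 2.0-fold higher number from compound 3 to compound 4 (0.30 log units; within the scatter). Compound 4 is estimated at 2 nM, with a range from 0.8 nM to 5 nM.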

Compound 4, half-maximal inhibitory concentration: 5 nM
The estimate for compound 4 lay 2.5-fold (0.40 log units) below the measured number; low and high end bracket the measured number.
By their numbers in this assay, from the lowest: compounds 3, 2, 1 and 4 (each within the scatter of the next, the first and the last beyond it).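

In this assay, the earlier amino groups gave no hint of a real loss at this position, but (pentan-3-yl)amino gives a higher number beyond the scatter against two of them (a 5.0-fold higher number from compound 3 to compound 4 (0.70 log units; beyond the scatter); a 3.4-fold higher number from compound 2 to compound 4 (0.53 log units; beyond the scatter)). Against (2-cyanoethyl)(ethyl)amino it stays within the scatter (a 2.0-fold higher number from compound 1 to compound 4 (0.30 log units; within the scatter)). For the compounds shown here, the change also brings a hydrogen-bond donor that diallylamino lacks, but no evidence links the step to this or any other feature. Still open, going by these compounds, is whether a methyl group on that amino nitrogen would bring the number back toward that of compound 3, and how a morpholine ring would read here.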